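Carbamate-linked dicarboxylic acids: extending the chain

This account rests on a few compounds, and the source may have more. Where it says the series, first, only, none or still open, it means among the compounds named here.

The three measured compounds share a core bearing a sugar on a saturated ring and a dicarboxylic acid at the end of a side chain. Compound 1, `CC1OC(OC2CCCCC2OCCCCCCC(C(=O)O)C(=O)O)C(O)C(O)C1O`, carries the acid on an ether-linked chain; in a functional assay on HL-60 cells (Homo sapiens) for inhibition (a higher number here means a weaker inhibitor, a lower number a stronger inhibitor), compound 1 reaches only the assay limit of > 5000000 nM. Compound 2, `CC1OC(OC2CCCCC2OCCCCCCCCC(C(=O)O)C(=O)O)C(O)C(O)C1O`, lengthens that chain, and in this assay compound 2 likewise reaches only the limit of > 5000000 nM. The step from the one to the other is therefore a step that the two limits leave unreadable from compound 1 to compound 2, as both values sit at the limit of > 5000000 nM in this assay, at which 2 of the 3 values shown sit. Compound 3, `CC1OC(OC2CCCCC2OC(=O)NCCC(C(=O)O)C(=O)O)C(O)C(O)C1O`, replaces the ether by a carbamate, and in this assay compound 3 gives 3500000 nM. Of the three, only compound 3 yields an actual number.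

Compound 4, `CC1OC(OC2CCCCC2OC(=O)NCCCCC(C(=O)O)C(=O)O)C(O)C(O)C1O`, differs from compound 3 by 3,3-dicarboxypropyl in place of dicarboxymethyl on a saturated chain carbon, two bonds along the chain from an amide-type nitrogen. Going by the values given here, the only comparable change, between compound 1 and compound 2, is unreadable because both sit at the limit, so no measured step gives the direction or size. The expectation is therefore a step of a 1.1-fold higher number from compound 3 to compound 4 (0.06 log units; within the scatter), essentially none beyond the scatter. Compound 4 is expected to give 4000000 nM, with a range from 1500000 nM to 10000000 nM, and a fair chance that this assay reports only a limit.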

Compound 4, half-maximal inhibitory concentration: 4500000 nM
For compound 4 the middle estimate is 1.1-fold (0.05 log units) below the measured one; measured number inside the range.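

In this assay, the carbamate-linked pair gives the first readable measure of this change: placing 3,3-dicarboxypropyl in place of dicarboxymethyl on a saturated chain carbon, two bonds along the chain from an amide-type nitrogen, gives a 1.3-fold higher number from compound 3 to compound 4 (0.11 log units; within the scatter). The two carbamate compounds therefore cannot be told apart, and the longer chain shows no gain in inhibition at this position. The corresponding step on the ether-linked chain cannot be read, since compound 1 and compound 2 each give only a limit: the limit of > 5000000 nM in this assay, at which 2 of the 4 values shown sit.

The compounds shown leave open whether any other group at the end of this chain, such as a phosphonic acid or a single carboxylic acid in place of the two carboxylic acids, would move the number beyond the scatter. Going by these compounds alone, no pair among them differs in the linker alone, so the part played by the carbamate remains unread.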